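A few compounds are considered here, and "the series" means these few. Any claim that something is new, unique, unknown or untested is made for them only; others in the source may bear on it.

Measured so far in a functional assay on HCT-116 cells (Homo sapiens) for cytotoxicity, read by sulforhodamine B assay, with a stated time of 72 h; on this read-out lower numbers stand for stronger inhibition and higher numbers for weaker inhibition:
compound 1 `C=C1C(=O)O[C@@H]2CC(C)=C([C@@H](C)CCCOC(C)=O)[C@@H](OC(=O)COc3ccc(C(C)=O)cc3)[C@H]12`: 40100 nM
compound 2 `C=C1C(=O)O[C@@H]2CC(C)=C([C@@H](C)CCCOC(C)=O)[C@@H](OC(=O)COc3ccc4c(CC)noc4c3)[C@H]12`: 18300 nM

Among the compounds with values here, compound 1 holds the higher of the two numbers, and its only neighbour is compound 2, with the step of a 2.2-fold lower number from compound 1 to compound 2 (0.34 log units; beyond the scatter). The next analogue is compound 3 `C=C1C(=O)O[C@@H]2CC(C)=C([C@@H](C)CCCOC(C)=O)[C@@H](OC(=O)c3cccc(F)c3)[C@H]12`, which keeps the core of compound 1 and differs as follows: 3-fluorophenyl in place of (4-acetylphenoxy)methyl on a carbonyl carbon. Within the data shown here, only one measured step bears on this change, and it is an indirect guide, since it alters a group on an oxygen on a saturated carbon and leaves the carbonyl carbon as it is. That step, a 2.2-fold lower number from compound 1 to compound 2 (0.34 log units; beyond the scatter), was modest. Among the measured compounds shown here, no measured compound carries 3-fluorophenyl on a carbonyl carbon, so the expectation is weakly supported. In this assay, a small move to a lower number is expected, not clearly beyond the scatter. The expected step is a 1.6-fold lower number from compound 1 to compound 3 (0.21 log units; within the scatter). The estimated value for compound 3 is 25000 nM, with an expected range of 9000 nM to 60000 nM.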

Compound 3, half-maximal inhibitory concentration: 14500 nM
For compound 3 the middle estimate is 1.7-fold (0.24 log units) above the measured one, within the range that was stated.
By their numbers in this assay, from the lowest: compounds 3 and 2 (each within the scatter of the next); then compound 1.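

In this assay, the ester position on the core of compound 1 tolerates loss of the whole (4-acetylphenoxy)methyl group: with 3-fluorophenyl directly on the carbonyl carbon, the read-out shows a 2.8-fold lower number from compound 1 to compound 3 (0.44 log units; beyond the scatter). Within the data shown here, the entering group has fewer heavy atoms and no hydrogen-bond acceptors, so neither the aryloxy link nor the acetyl group is required to hold the activity seen in compound 1, and the two replacements so far both give lower numbers, with no compound going against this; compound 2 at 18300 nM and compound 3 at 14500 nM lie within the scatter of each other, although their acyl groups differ greatly in shape and size. Nothing available explains why the number falls with this change.

The change replaces the link and the ring substitution together, so the shift cannot be assigned to either, and the part played by fluorine remains undefined without the unsubstituted benzoyl ester. Also open, on these data alone, is how the series responds to an amine or a carboxylic acid on the aromatic ring, or to a free hydroxyl in place of the acetate on the side chain.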